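Benzylamino in place of phenoxy on the shared core

The source may report more compounds than this note shows. Statements on the series, on what has been measured and on what is new or still open speak of the compounds shown alone.

Compound 2 `Nc1cc(N)c2nc(-c3ccccc3)c(Oc3ccc(F)cc3)nc2c1` is known in a functional assay on SR cells (Homo sapiens) for inhibition, read by sulforhodamine B assay, with a stated time of 48 h (a higher number here means a weaker inhibitor of growth, a lower number a stronger inhibitor of growth), only by a limit: compound 2 gives < 100000 nM, a limit of the assay and not a number (the limit of < 100000 nM in this assay, at which 1 of the 3 values shown sits). Compound 1 `Nc1cc(N)c2nc(-c3ccccc3)c(NCc3ccc(Cl)c(Cl)c3)nc2c1` gives 6030 nM in this assay. Compound 3 `COc1cc(CNc2nc3cc(N)cc(N)c3nc2-c2ccccc2)cc(OC)c1OC` also stops at a limit in this assay: compound 3 gives < 50200 nM, again a limit rather than a number (the limit of < 50200 nM in this assay, at which 1 of the 3 values shown sits).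

Compound 4 `Nc1cc(N)c2nc(-c3ccccc3)c(NCc3ccc(F)cc3)nc2c1` is not yet measured; it differs from compound 2 by (4-fluorobenzyl)amino in place of 4-fluorophenoxy on an aromatic carbon.

For the measured compounds named here, no measured pair differs in one place, so the step size is open. A step beyond the scatter toward stronger growth inhibition in this assay is expected, because compound 1, which also carries a benzylamino group, gives 6030 nM. The expected step is a step that the limit leaves unreadable from compound 2 to compound 4. Compound 4 is estimated at 12000 nM, between 3000 nM and 50000 nM.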

Compound 4, concentration for total growth inhibition: < 100000 nM
Compound 4 was reported as a limit; the forecaster's own chance of this, stated with the estimate: 30%; the middle value lies beyond the limit too.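

In this assay compound 4 gives < 100000 nM as a limit of the assay and not a number. For the compounds shown here, no step from compound 1 or compound 2 to compound 4 can be read. From the compounds shown here alone, the size of any effect of (4-fluorobenzyl)amino in place of 4-fluorophenoxy stays open.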